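The source may hold more compounds than are shown below. What is called first, only, known or untested is meant among the compounds shown, and "the series" means these compounds.

Three compounds have been examined in an ADME assay on HEL cells (Homo sapiens) for cytotoxicity, read by microscopy, with a stated time of 6 days; a higher number here means that more compound is tolerated, a lower number that less compound is tolerated. Compound 1 `CCCCCNc1cnc(C(=O)NCc2ccccc2)cn1` gives > 100000 nM there, which is a limit of the assay rather than a number. Compound 2 `CCCCNc1cnc(C(=O)NCc2ccccc2)cn1` likewise gives > 100000 nM, again a limit. Among the measured compounds shown here, compound 3 `CCCCCCNc1nccnc1C(=O)NCc1ccccc1` gives 100000 nM, the only value among the three that is a number. The change from compound 2 to compound 1 is methyl in place of hydrogen on a saturated chain carbon, four bonds along the chain from a nitrogen on an aromatic ring and its step is a step that the two limits leave unreadable from compound 2 to compound 1. How the core of compound 3 differs from that of compound 2 is not broken down here.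

Compound 4 `CCCCCCCNc1nccnc1C(=O)NCc1ccccc1` has not yet been measured. It differs from compound 3 by methyl in place of hydrogen on a saturated chain carbon, six bonds along the chain from a nitrogen on an aromatic ring, the same kind of change as that from compound 2 to compound 1, the place being six bonds along the chain rather than four. Beside a step that the two limits leave unreadable from compound 2 to compound 1, the step of no change at the digits printed from compound 3 to compound 4 (within the scatter) is expected to be small, resting on (the limit of > 100000 nM in this assay, at which 2 of the 3 values shown sit). Compound 4 is thus estimated at 100000 nM.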

Compound 4, minimum cytotoxic concentration: 100000 nM
Compound 4: middle estimate and measured number agree at the digits printed; low and high end bracket the measured number.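

In this assay, methyl in place of hydrogen on the core of compound 3 gives no change at the digits printed from compound 3 to compound 4 (within the scatter). The same kind of change on the other core, between compound 2 and compound 1, cannot be read, as both values are limits of the assay: the limit of > 100000 nM in this assay, at which 2 of the 4 values shown sit.
The change is therefore seen with a readable result on one core only and at one place on the chain, so this does not show whether it carries from one core to another.

The compounds shown leave open how a chain ending in an amine or a carboxylic acid would read in this assay. They also leave open whether a chain longer than that of compound 4 would stay at the same level on either core.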